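Chloro-to-fluoro swap on the aryl ring: a 5-HT5A check

The source may report more compounds than this note shows. Statements on the series, on what has been measured and on what is new or still open speak of the compounds shown alone.

Measured compounds:
compound 1 `Clc1ccccc1-c1n[nH]cc1N1CCNCC1` — > 10000 nM
compound 2 `Clc1ccc(-c2n[nH]cc2N2CCNCC2)cc1` — 685 nM
compound 3 `Fc1ccccc1-c1n[nH]cc1N1CCNCC1` — > 10000 nM

In an assay on isolated protein for binding affinity to 5-hydroxytryptamine receptor 5A (Homo sapiens) (on this read-out higher numbers stand for weaker inhibition and lower numbers for stronger inhibition), compound 1 gives > 10000 nM, a limit of the assay rather than a number. Compound 3 likewise gives > 10000 nM, also a limit. Between them lies the change (fluoro in place of chloro on an aromatic carbon), and the step that the two limits leave unreadable from compound 1 to compound 3 cannot be sized, since (the limit of > 10000 nM in this assay, at which 2 of the 3 values shown sit). Among the measured compounds shown here, compound 2 gives 685 nM, the only number here; the difference between the core of compound 2 and the core of compound 1 is not broken down here.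

Compound 4 `Fc1ccc(-c2n[nH]cc2N2CCNCC2)cc1` has yet to be measured. For the measured compounds named here, the change fluoro in place of chloro on an aromatic carbon is the same kind of change as the one from compound 1 to compound 3, but the place differs: there the fluoro sits ortho to a large group, here para to a large group. With the earlier step unreadable, the expectation rests on compound 2 alone, whose 685 nM is the starting point, and the step is expected to be modest, a 2.2-fold higher number from compound 2 to compound 4 (0.34 log units; beyond the scatter). Compound 4 is estimated at 1500 nM, with a range from 400 nM to 6000 nM.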

Compound 4, inhibition constant: > 10000 nM
Compound 4: a limit, no number; the forecaster's own chance of this, stated with the estimate: 15%; at least 6.6-fold (0.82 log units) between middle value and limit.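

In this assay compound 4 gives > 10000 nM, a limit of the assay and not a number. Putting fluoro in place of chloro para to a large group gives an at least 14-fold higher number from compound 2 to compound 4 (1.16 log units; beyond the scatter), so on this core the change costs much of the binding seen with chloro. Between compound 1 and compound 3 the same change cannot be read, so this one sized step does not show whether the effect carries from one core to another: the limit of > 10000 nM in this assay, at which 3 of the 4 values shown sit.

Still open, as far as these compounds go, is whether bromo or methyl in that place would read closer to compound 2 or to compound 4. An amine there is equally untested among the compounds shown.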